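Notes on methoxy additions and Vero cell tolerance

The compounds below may be only part of what the source reports. "The series", "measured", "known", "first", "only" and "open" are said of these compounds alone.

Measured so far:
compound 1, `COc1ccc(/C=C/C(=O)NCCNc2ccnc3cc(Cl)ccc23)cc1`: 20600 nM
compound 2, `COc1ccc(/C=C/C(=O)NCCNc2ccnc3cc(Cl)ccc23)cc1OC`: 5600 nM
compound 3, `COc1ccc(/C=C/C(=O)c2ccccc2OCC(=O)NCCNc2ccnc3cc(Cl)ccc23)cc1OC`: 5310 nM

In an ADME assay on Vero cells (Chlorocebus sabaeus) for cytotoxicity, read by MTT assay, with a stated time of 72 h (a lower number here means that less compound is tolerated, a higher number that more compound is tolerated), compound 1 gives 20600 nM. Compound 2 carries one change, (methoxy in place of hydrogen on an aromatic carbon), and the step is a 3.7-fold lower number from compound 1 to compound 2 (0.57 log units; beyond the scatter). Compound 3 gives 5310 nM in this assay; the difference between the core of compound 1 and the core of compound 3 is not broken down here. The values of compound 2 and compound 3 lie within the scatter of each other.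

Compound 4, `COc1cc(/C=C/C(=O)c2ccccc2OCC(=O)NCCNc2ccnc3cc(Cl)ccc23)cc(OC)c1OC`, is not yet measured. It differs from compound 3 by methoxy in place of hydrogen on an aromatic carbon. This is the same kind of change as that from compound 1 to compound 2, but the surroundings differ: in compound 4 the aromatic carbon is also meta to a methoxy group, and the change reads 3,4-dimethoxyphenyl to 3,4,5-trimethoxyphenyl.

A lower number is expected for compound 4, with an estimated step of a 1.7-fold lower number from compound 3 to compound 4 (0.22 log units; within the scatter). This expected step is held more modest than the step measured earlier, a 3.7-fold lower number from compound 1 to compound 2 (0.57 log units; beyond the scatter), because compound 3 already gives 5310 nM, well below the value of compound 1. The estimate for compound 4 in this assay is 3200 nM, between 1500 nM and 7500 nM.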

Compound 4, half-maximal cytotoxic concentration: 3920 nM
For compound 4 the middle estimate is 1.2-fold (0.09 log units) below the measured one; low and high end bracket the measured number.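

In this assay, the added methoxy that turns 3,4-dimethoxyphenyl into 3,4,5-trimethoxyphenyl gives a 1.4-fold lower number from compound 3 to compound 4 (0.13 log units; within the scatter), so on this core the change cannot be told apart from repeat-measurement noise. The size of the step does not carry over from the core of compound 1 to the core of compound 3: the same change on two cores in this assay, a 3.7-fold lower number (0.57 log units; beyond the scatter) from compound 1 to compound 2 and a 1.4-fold lower number (0.13 log units; within the scatter) from compound 3 to compound 4, 2.7-fold (0.43 log units) apart, beyond the scatter of two such steps. This rests on one pair per core, and the two pairs differ both in the core and in the methoxy groups already present on the ring, so the gap cannot be assigned to either difference and no rule for the series follows from it.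

The compounds shown leave open whether a hydroxy group or a chlorine in place of the added methoxy would behave alike on both cores. They also leave open whether the gap between the steps persists when the chain carrying the amide is replaced by a longer chain.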